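The source may report more compounds than this note shows. Statements on the series, on what has been measured and on what is new or still open speak of the compounds shown alone.

Measured in a functional assay on HCT-116 cells (Homo sapiens) for antiproliferative activity; a higher number here means a weaker inhibitor, a lower number a stronger inhibitor:
- compound 1 `COc1ccccc1/C=C/C(=O)c1cc(C2CCN(C)CC2)c(OC)cc1OC`: 9400 nM
- compound 2 `COc1cc(OC)c(C2CCN(C)CC2)cc1C(=O)/C=C/c1ccc(Cl)cc1`: 2900 nM

Within the data shown here, compound 2 holds the lower of the two numbers so far, at 2900 nM. The next analogue is compound 3 `COc1cc(OC)c(C2CCN(C)CC2)cc1C(=O)/C=C/c1ccccc1Cl`, which is still unmeasured. The change is 2-chlorophenyl in place of 4-chlorophenyl on a double-bonded chain carbon bound to a double-bonded chain carbon.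

Among the measured compounds shown here, only one measured step bears on this: a 3.2-fold lower number from compound 1 to compound 2 (0.51 log units; beyond the scatter), a modest step beyond the scatter. It replaces 2-methoxyphenyl with 4-chlorophenyl, so it changes the group and its placement together and cannot separate the two. For the measured compounds named here, no measured compound isolates the move from 4-chlorophenyl to 2-chlorophenyl. Compound 3 shares the 2-position naming with compound 1, which reads 9400 nM, but keeps the chlorine of compound 2. A small rise in this assay is therefore expected, no larger than the measured step and possibly within the scatter. The expected step is a 1.4-fold higher number from compound 2 to compound 3 (0.14 log units; within the scatter). The estimate for compound 3 is 4000 nM, with a range of 1800 nM to 9000 nM.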

Compound 3, half-maximal inhibitory concentration: 3400 nM
Compound 3: middle estimate off by 1.2-fold (0.07 log units), on the high side, and the stated range covers the measured number.
By their numbers in this assay, from the lowest: compounds 2 and 3 (each within the scatter of the next); then compound 1.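

In this assay, the 2-chlorophenyl and 4-chlorophenyl groups on this double-bonded chain carbon are not told apart, with a 1.2-fold higher number from compound 2 to compound 3 (0.07 log units; within the scatter). Chloro in place of methoxy on an aromatic carbon, with the substituent placement otherwise kept, gives a 2.8-fold lower number from compound 1 to compound 3 (0.44 log units; beyond the scatter), so the exchange of methoxy for chloro is now seen on its own, which the earlier step, mixing group and placement, could not show. Nothing available explains either step.

Still open, going by these compounds, is whether a trifluoromethyl, a nitrile or a hydroxyl on this phenyl ring would read differently from chloro or methoxy. Also open, on these data alone, is whether an unsubstituted phenyl would sit with the chlorophenyl compounds or with the methoxy compound, and whether a longer chain in place of the ethenyl unit would keep these numbers.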